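Adding a methyl to the hydroxy group of compound 2

The source may hold more compounds than are shown below. What is called first, only, known or untested is meant among the compounds shown, and "the series" means these compounds.

Values in an ADME assay on MT4 cells (Homo sapiens) for cytotoxicity, read by MTT assay, with a stated time of 4 days; on this read-out lower numbers stand for higher toxicity in this test and higher numbers for lower toxicity in this test:
- Compound 1 `COc1cccc(-c2oc3ccc(NC(C)=O)cc3c(=O)c2O)c1` gives 33300 nM 
- Compound 2 `CC(=O)Nc1ccc2oc(-c3cccc(C(F)(F)F)c3)c(O)c(=O)c2c1` gives 5700 nM 

Compound 2 holds the lower of the two numbers, so it is the more toxic in this test. Compound 3 `COc1c(-c2cccc(C(F)(F)F)c2)oc2ccc(NC(C)=O)cc2c1=O` differs from it in one place, where hydroxy becomes methoxy: methyl in place of hydrogen on an oxygen on an aromatic ring. Within the data shown here, the only measured step is a 5.8-fold lower number from compound 1 to compound 2 (0.77 log units; beyond the scatter), a modest change made at another place, trifluoromethyl in place of methoxy on an aromatic carbon. No measured pair changes this oxygen, so the direction is not shown and that step offers only a rough size. In this assay, among the measured compounds shown here, a step no larger than it is expected, perhaps within the scatter, tilted towards a higher number since compound 2 at 5700 nM is the lower of only two values. The expected step is a 1.8-fold higher number from compound 2 to compound 3 (0.24 log units; within the scatter) and remains a rough estimate. Compound 3 is estimated at 10000 nM with an expected range of 3000 nM to 33000 nM in this test.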

Compound 3, half-maximal cytotoxic concentration: 201000 nM
Beside the measured number, compound 3's estimate is 20-fold (1.30 log units) below it; measured number above the stated range.
By their numbers in this assay, from the lowest: compound 2; then compound 1; then compound 3.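

In this assay, among these compounds, the hydroxy group turns out to matter far more than the earlier compounds could show: replacing its hydrogen with methyl, which adds a single carbon, gives a large move towards lower toxicity in this test (a 35-fold higher number from compound 2 to compound 3 (1.55 log units; beyond the scatter)). This step is also larger than the only earlier one, made on an aromatic carbon (a 5.8-fold lower number from compound 1 to compound 2 (0.77 log units; beyond the scatter)), so in this small set the oxygen is the more sensitive of the two places. No measurement at hand explains why this change has such an effect.

Only hydrogen and methyl are shown on this oxygen, so it remains open whether a longer chain such as ethyl, or an acetyl group, would act like methyl. As far as these compounds go, it is also open whether the same change made on compound 1 would give a step of similar size.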